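This account rests on a few compounds, and the source may have more. Where it says the series, first, only, none or still open, it means among the compounds named here.

Measured compounds:
compound 1, `C[C@H](NC(=S)Nc1cc(C(F)(F)F)cc(C(F)(F)F)c1)c1nc2ccccc2[nH]1`, 154000 nM
compound 2, `CC(C)[C@@H](NC(=S)Nc1cc(C(F)(F)F)cc(C(F)(F)F)c1)c1nc2ccccc2[nH]1`, 20200 nM
compound 3, `CC(C)C[C@H](NC(=S)Nc1cc(C(F)(F)F)cc(C(F)(F)F)c1)c1nc2ccccc2[nH]1`, 17200 nM

The three compounds were tested in a functional assay on DU-145 cells (Homo sapiens) for cytotoxicity, read by MTT assay; a lower number here means a stronger inhibitor, a higher number a weaker inhibitor. Compound 3 gives the lowest number of the three in this assay. Its nearest neighbour is compound 2, a gap that lies within the scatter, so the two cannot be ordered against each other. Going by the values given here, compound 1 stands furthest away, and the single step that can be read between compounds differing in one place is a 9.0-fold lower number from compound 1 to compound 3 (0.95 log units; beyond the scatter), a modest gain.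

Compound 4, `CC(C)[C@H](NC(=S)Nc1cc(C(F)(F)F)cc(C(F)(F)F)c1)c1nc2ccccc2[nH]1`, has not yet been measured in this assay. It differs from compound 3 as follows: isopropyl in place of isobutyl on a saturated chain carbon bound to an amide-type nitrogen and an aromatic carbon. Among the compounds with values here, the only measured step concerns a different exchange, hydrogen for isopropyl on that chain carbon, and so bears on the present change only loosely; no step between compound 2 and compound 4 is computed here. Compound 2 and compound 3, the two compounds carrying a branched group at that carbon, give numbers within the scatter of each other. Compound 4 is therefore expected to stay close to compound 3, with a step of a 1.2-fold higher number from compound 3 to compound 4 (0.09 log units; within the scatter), within the scatter. The estimate for compound 4 in this assay is 21000 nM, with a range from 8000 nM to 60000 nM.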

Compound 4, half-maximal inhibitory concentration: 26100 nM
The estimate for compound 4 lay 1.2-fold (0.09 log units) below the measured number; measured number inside the range.
By their numbers in this assay, from the lowest: compounds 3, 2 and 4 (each within the scatter of the next); then compound 1.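

In this assay, isopropyl in place of isobutyl on the saturated chain carbon bound to an amide-type nitrogen and an aromatic carbon gives a 1.5-fold higher number from compound 3 to compound 4 (0.18 log units; within the scatter), so this exchange between two branched groups does not separate the compounds. The result also brings in something the earlier compounds could not show, the drawn configuration at this carbon, and with isopropyl in place it gives a 1.3-fold higher number from compound 2 to compound 4 (0.11 log units; within the scatter), so neither configuration can be preferred, a reading that can be tied to the stereocentre alone for one reason: the fact that compounds 2 and 4 differ only in the configuration as drawn Against this flat picture among the isopropyl and isobutyl compounds, methyl remains the group that stands apart, with a 5.9-fold lower number from compound 1 to compound 4 (0.77 log units; beyond the scatter).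

The compounds shown leave open whether the drawn configuration would count with methyl or isobutyl at this carbon, since the comparison here rests on the isopropyl pair alone. They also leave open whether an ethyl group, a longer chain, a benzyl group or an amine at the same carbon would stay level with compound 3 and compound 4 or move away from them.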